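Aryl variation on the fused core: the step to compound 4

The compounds below may be only part of what the source reports. "The series", "measured", "known", "first", "only" and "open" are said of these compounds alone.

Three compounds of the series carry a number in a functional assay on HT-29 cells (Homo sapiens) for inhibition, with a stated time of 72 h; on this read-out lower numbers stand for stronger inhibition and higher numbers for weaker inhibition:

compound 1 `COc1ccc(S(=O)(=O)N2CCc3cccc(-c4ccc(F)nc4)c32)cc1` gives 109 nM
compound 2 `COc1ccc(S(=O)(=O)N2CCc3cccc(-c4ccco4)c32)cc1` gives 62.5 nM
compound 3 `COc1ccc(S(=O)(=O)N2CCc3cccc(-c4ccc(O)cc4)c32)cc1` gives 133 nM

Compound 2 holds the lowest of the three numbers. Its nearest neighbour is compound 1, with a 1.7-fold lower number from compound 1 to compound 2 (0.24 log units; within the scatter), a step inside the scatter. The step of a 2.1-fold higher number from compound 2 to compound 3 (0.33 log units; beyond the scatter) lies beyond the scatter, though only modestly. Between the two six-membered aryl compounds the step of a 1.2-fold higher number from compound 1 to compound 3 (0.09 log units; within the scatter) is inside the scatter, so compound 1 and compound 3 cannot be separated on this read-out.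

Compound 4 `COc1ccc(S(=O)(=O)N2CCc3cccc(-c4ccc(C#N)cc4)c32)cc1` has no number yet in this assay. Its change from compound 2 is 4-cyanophenyl in place of furan-2-yl on an aromatic carbon. Within the data shown here, two measured steps bear on it: a 2.1-fold higher number from compound 2 to compound 3 (0.33 log units; beyond the scatter), which likewise trades furan-2-yl for a six-membered ring, and a 1.7-fold lower number from compound 1 to compound 2 (0.24 log units; within the scatter), which runs the other way between a six-membered ring and furan-2-yl. Both place the six-membered aryl compounds at a somewhat higher number than compound 2, one inside and one just beyond the scatter. A small upward step is therefore expected, of about a 1.8-fold higher number from compound 2 to compound 4 (0.25 log units; within the scatter), near the edge of what repeats would resolve. Compound 4 is estimated at 110 nM, within a range from 50 nM to 250 nM.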

Compound 4, half-maximal inhibitory concentration: 24.2 nM
Beside the measured number, compound 4's estimate is 4.5-fold (0.66 log units) above it, and the stated range ends above it.
By their numbers in this assay, from the lowest: compound 4; then compounds 2, 1 and 3 (each within the scatter of the next, the first and the last beyond it).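

In this assay, among these compounds, the earlier compounds spanned little at this aromatic carbon, and both six-membered aryl compounds carried a higher number than furan-2-yl, though only one of those steps lay beyond the scatter. 4-Cyanophenyl reverses that order (a 2.6-fold lower number from compound 2 to compound 4 (0.41 log units; beyond the scatter)), so a six-membered aromatic ring of carbon only at this position is not tied to a weaker result. The group carried on that ring also matters here: cyano in place of hydroxy gives the largest step in the set (a 5.5-fold lower number from compound 3 to compound 4 (0.74 log units; beyond the scatter)), and 4-cyanophenyl also separates from 6-fluoropyridin-3-yl (a 4.5-fold lower number from compound 1 to compound 4 (0.65 log units; beyond the scatter)), although compound 1 and compound 3 themselves cannot be separated. No supporting measurement accompanies these numbers, so the result remains without an explanation.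

The compounds shown do not settle whether the lower number belongs to the nitrile itself, a question that plain phenyl, or a carboxylic acid or primary amide in place of the nitrile, would bear on. On these data alone, how far the trend extends to larger groups at this aromatic carbon, such as a 4-(morpholinomethyl)phenyl group, also remains open.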